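The source may report more compounds than this note shows. Statements on the series, on what has been measured and on what is new or still open speak of the compounds shown alone.

Measured so far in an assay on HEK293 cells for displacement of a labelled ligand from Melanocortin receptor 4 (Homo sapiens); on this read-out lower numbers stand for stronger inhibition and higher numbers for weaker inhibition:
compound 1 `CC(C)C[C@H](N)c1cc(C(F)(F)F)ccc1N1CCN(C(=O)C(C)Cc2ccc(Cl)cc2)CC1` gives 47 nM
compound 2 `CC(C)C[C@H](N)c1cc(C(F)(F)F)ccc1N1CCN(C(=O)CCNC2CCCCC2)CC1` gives 4800 nM
compound 3 `CC(C)C[C@H](N)c1cc(C(F)(F)F)ccc1N1CCN(C(=O)COc2cccc(Cl)c2Cl)CC1` gives 2500 nM

Compound 3 stands second highest of the three numbers. Its nearest neighbour is compound 2, and the step of a 1.9-fold lower number from compound 2 to compound 3 (0.28 log units; within the scatter) lies within the scatter; the step of a 53-fold higher number from compound 1 to compound 3 (1.73 log units; beyond the scatter) is large and beyond it. Compound 4 `CC(C)C[C@H](N)c1cc(C(F)(F)F)ccc1N1CCN(C(=O)CCC2CCCCC2)CC1` differs from compound 3 by cyclohexylmethyl in place of 2,3-dichlorophenoxy on a saturated chain carbon bound to a carbonyl carbon. Within the data shown here, two measured steps bear on this change. The steps of a 100-fold higher number from compound 1 to compound 2 (2.01 log units; beyond the scatter) and a 53-fold higher number from compound 1 to compound 3 (1.73 log units; beyond the scatter) show that leaving the 1-(4-chlorobenzyl)ethyl chain of compound 1 for either of the other two chains costs a great deal in this assay, and a 1.9-fold lower number from compound 2 to compound 3 (0.28 log units; within the scatter) shows that the (cyclohexylamino)methyl and 2,3-dichlorophenoxy variants sit at about the same level. Among the measured compounds shown here, compound 4 shares the cyclohexyl ring of compound 2 but none of the acceptor atoms of compounds 2 or 3, and no measured pair shows the effect of that. Only a modest change, possibly within the scatter, is therefore expected. The estimate for compound 4 is 1200 nM, ranging from 250 nM to 6000 nM, which means an expected step of a 2.1-fold lower number from compound 3 to compound 4 (0.32 log units; beyond the scatter).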

Compound 4, inhibition constant: 5700 nM
Beside the measured number, compound 4's estimate is 4.8-fold (0.68 log units) below it; low and high end bracket the measured number.
By their numbers in this assay, from the lowest: compound 1; then compounds 3, 2 and 4 (each within the scatter of the next, the first and the last beyond it).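

In this assay, cyclohexyl in place of cyclohexylamino on the chain leaves the number within the scatter, a 1.2-fold higher number from compound 2 to compound 4 (0.07 log units; within the scatter), so the amine nitrogen of compound 2 shows no measurable contribution at this position. Cyclohexylmethyl in place of 2,3-dichlorophenoxy gives a 2.3-fold higher number from compound 3 to compound 4 (0.36 log units; beyond the scatter), a modest step that puts the 2,3-dichlorophenoxy chain ahead of the all-carbon cyclohexyl chain. A third chain also falls far from compound 1, with 2-cyclohexylethyl giving a 120-fold higher number from compound 1 to compound 4 (2.08 log units; beyond the scatter), so the saturated ring of compound 4 does not recover the level of the 1-(4-chlorobenzyl)ethyl chain. Nothing on hand accounts for these steps.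

Still open, on these data alone, is whether the chlorophenyl ring or the branching methyl of compound 1 carries its advantage. An unbranched 2-(4-chlorophenyl)ethyl chain and a 1-benzylethyl chain without chlorine would separate the two.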